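The source may report more compounds than this note shows. Statements on the series, on what has been measured and on what is new or still open speak of the compounds shown alone.

In a functional assay on A549 cells (Homo sapiens) for antiproliferative activity, read by CCK-8 assay, with a stated time of 72 h (a lower number here means a stronger inhibitor of growth, a higher number a weaker inhibitor of growth), compound 1 `CCCNS(=O)(=O)c1ccc(Nc2ncc3c(n2)N(C2CCCC2)[C@H](CC)C(=O)N3C)cc1` gives 563 nM, the lowest of the two numbers in hand. Compound 3 `CCCNC(=O)c1ccc2c(ccn2-c2ncc3c(n2)N(C2CCCC2)[C@H](CC)C(=O)N3C)c1` gives 1640 nM, a higher number than compound 1 and beyond the scatter. Compound 2 `CCC1C(=O)N(C)c2cnc(Nc3ccc(S(N)(=O)=O)cc3)nc2N1c1ccn(C)n1` is reported as "not active" (no number reported), with no number given. Compound 4 `CC[C@@H]1C(=O)N(C)c2cnc(Nc3ccc(S(=O)(=O)Nc4ccccc4)cc3)nc2N1C1CCCC1` differs from compound 1 in one place: phenyl in place of propyl on a sulfonamide nitrogen. Within the data shown here, no measured pair carries this same change, so the size of the step is open. The shared core is kept and the change is confined to the sulfonamide nitrogen, so a step within the scatter or at most a small loss is expected, a 1.3-fold higher number from compound 1 to compound 4 (0.12 log units; within the scatter). Compound 4 is accordingly estimated at 750 nM, with a range from 250 nM to 2200 nM.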

Compound 4, concentration for 50% growth inhibition: 4150 nM
Estimate against measurement, compound 4: 5.5-fold (0.74 log units) below, and the stated range ends below it.
By their numbers in this assay, from the lowest: compound 1; then compound 3; then compound 4.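

The sulfonamide nitrogen is not a silent position in this assay: phenyl in place of propyl gives a 7.4-fold higher number from compound 1 to compound 4 (0.87 log units; beyond the scatter). Growth inhibition in this pair therefore depends on the group carried on this nitrogen, and the aromatic ring with its larger heavy-atom count is the weaker of the two substituents. Nothing measured here accounts for the change. From the compounds shown here alone, one pair sets no trend, and whether the ring itself or the size of the group matters stays open. A benzyl group, a butyl chain or a chain ending in an amine on this nitrogen would help separate the two.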